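Swapping a dipropylamino for a (1-methylbutyl)amino group

A few compounds are considered here, and "the series" means these few. Any claim that something is new, unique, unknown or untested is made for them only; others in the source may bear on it.

Measured compounds:
compound 1 `CCC(CC)Nc1nc(C)nc2c(-c3c(C)cc(N(C)C)nc3C)c(C)nn12`: 25.6 nM
compound 2 `CCCN(CCC)c1nc(C)nc2c(-c3ccc(OC)nc3C)c(C)nn12`: 5.7 nM
compound 3 `CCC(CC)Nc1nc(C)nc2c(-c3cnc(N(C)C)cc3C)c(C)nn12`: 24.8 nM

In an assay on cell membranes for displacement of a labelled ligand from corticotropin-releasing factor receptor 1 (Rattus norvegicus) (a higher number here means a weaker inhibitor, a lower number a stronger inhibitor), compound 2 gives the lowest of the three numbers; compound 3 and compound 1 sit well above it, both beyond the scatter. Compound 4 `CCCC(C)Nc1nc(C)nc2c(-c3ccc(OC)nc3C)c(C)nn12` is compound 2 with one change: (1-methylbutyl)amino in place of dipropylamino on an aromatic carbon. Among the compounds with values here, no measured pair isolates this change. Within the data shown here, the only measured step, a 1.0-fold lower number from compound 1 to compound 3 (0.01 log units; within the scatter), alters a methyl on the pyridine ring and says nothing about the amine. Compounds 1 and 3 carry a branched secondary amine like compound 4, yet also a different pyridine substituent, so their higher values cannot be attributed to the amine alone. With nothing to argue for a large shift, compound 4 is expected to stay near compound 2, the step of a 1.8-fold higher number from compound 2 to compound 4 (0.24 log units; within the scatter) being within or just beyond the scatter. Compound 4 is estimated at 10 nM, within 3 nM to 35 nM.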

Compound 4, half-maximal inhibitory concentration: 3.5 nM
Estimate against measurement, compound 4: 2.9-fold (0.46 log units) above; the range from low to high includes it.
By their numbers in this assay, from the lowest: compounds 4 and 2 (each within the scatter of the next); then compounds 3 and 1 (each within the scatter of the next).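

In this assay, putting (1-methylbutyl)amino in place of dipropylamino gives a 1.6-fold lower number from compound 2 to compound 4 (0.21 log units; within the scatter) and so leaves the number unchanged within the scatter. Within the data shown here, this is the first pair in which the amine alone differs, and it shows that this position, between two ring nitrogen atoms, tolerates the exchange of a group with no hydrogen-bond donor for one with a hydrogen-bond donor, with the rest of the molecule held constant. Nothing on hand explains why the two amines read alike.

Among these compounds, with only this one pair, it remains open how a ring amine such as morpholine, or a much shorter group such as methylamino, would read here. From the compounds shown here alone, it is also open whether the same exchange would hold on compounds carrying a dimethylamino group on the pyridine ring.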